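The compounds below may be only part of what the source reports. "The series", "measured", "known", "first", "only" and "open" are said of these compounds alone.

Measured compounds in an ADME assay for permeability, using PAMPA, with a stated time of 30 min, at pH 7.4; on this read-out lower numbers stand for lower permeability and higher numbers for higher permeability:
compound 1 `c1ccc(Oc2ccc3c(NCCCNCc4ccco4)ccnc3c2)cc1`: 317 10^-6 cm/s
compound 2 `Fc1ccc(Cc2ccc3c(NCCCNCc4ccco4)ccnc3c2)c(Cl)c1`: 23 10^-6 cm/s
compound 3 `c1ccc(CCc2ccc3c(NCCCNCc4ccco4)ccnc3c2)cc1`: 23 10^-6 cm/s

Compound 3 stands level with compound 2 at the digits given, the two together at the low end of the three numbers; compound 1 sits well apart, with a 14-fold lower number from compound 1 to compound 3 (1.14 log units; beyond the scatter).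

Compound 4 `c1coc(CNCCCNc2ccnc3cc(C4CCCCC4)ccc23)c1` differs from compound 3 by cyclohexyl in place of phenethyl on an aromatic carbon.

The steps measured so far all concern the phenoxy group and its replacements: a 14-fold lower number from compound 1 to compound 2 (1.14 log units; beyond the scatter) and a 14-fold lower number from compound 1 to compound 3 (1.14 log units; beyond the scatter) were large, while no change at the digits printed from compound 2 to compound 3 (within the scatter) was within the scatter. For the measured compounds named here, no measured step swaps a phenethyl for a cyclohexyl, so the present change is only loosely informed. The ring-bearing replacements of phenoxy in compounds 2 and 3 both gave low numbers, and a directly attached cyclohexyl is expected to stay within a modest, uncertain distance of that level, with a 1.7-fold higher number from compound 3 to compound 4 (0.24 log units; within the scatter) as the expected step.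

Compound 4 is estimated at 40 10^-6 cm/s, likely between 12 10^-6 cm/s and 130 10^-6 cm/s.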

Compound 4, apparent permeability: 23 10^-6 cm/s
Compound 4: the middle estimate sits 1.7-fold (0.24 log units) above what was measured; low and high end bracket the measured number.
By their numbers in this assay, from the lowest: compounds 2, 3 and 4 (each within the scatter of the next); then compound 1.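

In this assay, a directly attached cyclohexyl gives no change at the digits printed from compound 3 to compound 4 (within the scatter) and no change at the digits printed from compound 2 to compound 4 (within the scatter), so a non-aromatic carbon ring at this position stands with the phenethyl and 2-chloro-4-fluorobenzyl groups. Phenoxy remains the outlier among the four, with a 14-fold lower number from compound 1 to compound 4 (1.14 log units; beyond the scatter), and the gap now holds across three different replacements. No measurement at hand accounts for that gap.

Still open, going by these compounds, is whether other oxygen-linked groups, such as benzyloxy or methoxy, match compound 1 317 10^-6 cm/s. An amine-linked phenyl at the same aromatic carbon would test whether oxygen itself is needed.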